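Swapping the tert-butylphenyl arm for a benzodioxinyl ring

The compounds below may be only part of what the source reports. "The series", "measured", "known", "first", "only" and "open" are said of these compounds alone.

Two sulfonamide-linked amines have been tested in a functional assay on MIA PaCa-2 cells (Homo sapiens) for inhibition, read by MTT assay, with a stated time of 72 h; a lower number here means a stronger inhibitor of growth, a higher number a weaker inhibitor of growth. Compound 1 `CC(C)(C)c1ccc(CNCCCNS(=O)(=O)c2cc(C(F)(F)F)cc(C(F)(F)F)c2)cc1` gives 2300 nM in this assay, the lowest of the two numbers. Compound 2 `O=[N+]([O-])c1ccc(S(=O)(=O)NCCCCCCNCc2ccc(Br)cc2)cc1` gives 9800 nM in this assay, a weaker inhibitor than compound 1 by a margin that is beyond the usual scatter. Compound 3 `O=S(=O)(NCCCNCC1COc2ccccc2O1)c1cc(C(F)(F)F)cc(C(F)(F)F)c1` has not been measured yet. It differs from compound 1 in one place: 2,3-dihydro-1,4-benzodioxin-2-yl in place of 4-(tert-butyl)phenyl on a saturated chain carbon bound to an amine nitrogen. Among the compounds with values here, nothing measured so far describes this particular swap, so the size of its effect is unknown. The expectation is that compound 3 comes out modestly weaker than compound 1, with a step of a 2.0-fold higher number from compound 1 to compound 3 (0.29 log units; within the scatter) that may or may not exceed the scatter. Compound 3 is therefore estimated at 4500 nM in this assay, within a range from 1500 nM to 14000 nM.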

Compound 3, concentration for 50% growth inhibition: 2600 nM
Estimate against measurement, compound 3: 1.7-fold (0.24 log units) above; the measured number falls inside the stated range.
By their numbers in this assay, from the lowest: compounds 1 and 3 (each within the scatter of the next); then compound 2.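

At the saturated chain carbon bound to an amine nitrogen, putting 2,3-dihydro-1,4-benzodioxin-2-yl in place of 4-(tert-butyl)phenyl gives a 1.1-fold higher number from compound 1 to compound 3 (0.05 log units; within the scatter) in this assay. Within the data shown here, this is the first reading of any change at this place, and it shows that a group with 0 hydrogen-bond acceptors can give way to one with 2, holding 2 oxygen atoms, with no difference that stands out from the scatter. Nothing measured here bears on why the two compounds read alike.

On these data alone, whether other groups at this place would also read alike stays open, for example a plain cyclohexyl ring or a phenyl ring carrying a carboxylic acid. Compound 2 differs from compound 1 and compound 3 in more than one place, so it cannot help to settle this.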